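Compound 2 to compound 4: removing the amino-acid tail

The compounds below may be only part of what the source reports. "The series", "measured", "known", "first", "only" and "open" are said of these compounds alone.

In a functional assay on HepG2 cells (Homo sapiens) for antiproliferative activity, read by CCK-8 assay, with a stated time of 48 h (on this read-out lower numbers stand for stronger inhibition and higher numbers for weaker inhibition), compound 2 `COc1ccc(/C=C\c2cc(OC)c(OC)c(OC)c2)cc1OCc1ccc(CN[C@H](C(=O)O)[C@H](C)O)cc1` returns only the limit > 10000 nM, not a number. Compound 1 `COc1ccc(/C=C\c2cc(OC)c(OC)c(OC)c2)cc1OCc1ccc(CN2CC[C@H](C(=O)O)C2)cc1` gives 6400 nM in this assay, and compound 3 `COc1ccc(/C=C\c2cc(OC)c(OC)c(OC)c2)cc1OCc1ccc(CN2CC[C@@H](O)C2)cc1` gives 6200 nM. The measured steps of an at least 1.5-fold higher number from compound 1 to compound 2 (0.19 log units; that floor lies within the scatter) and an at least 1.6-fold lower number from compound 2 to compound 3 (0.20 log units; that floor lies within the scatter) each exchange one amine tail for another, and a 1.0-fold lower number from compound 1 to compound 3 (0.01 log units; within the scatter) does the same; all three sit within the scatter. Compound 4 `COc1ccc(/C=C\c2cc(OC)c(OC)c(OC)c2)cc1OCc1ccc(C=O)cc1` differs from compound 2 by formyl in place of ((1-carboxy-2-hydroxypropyl)amino)methyl on an aromatic carbon. Among the compounds with values here, no measured step removes the whole tail, so the three steps bear only loosely; they show that varying this position has moved the number little. The estimated step of an at least 2.5-fold lower number from compound 2 to compound 4 (0.39 log units; beyond the scatter) is therefore expected to be modest and downward. Compound 4 is expected to give about 4000 nM, within 1000 nM to 15000 nM.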

Compound 4, half-maximal inhibitory concentration: 800 nM
For compound 4 the middle estimate is 5.0-fold (0.70 log units) above the measured one; the whole stated range lies above it.
By their numbers in this assay, from the lowest: compound 4; then compounds 3 and 1 (each within the scatter of the next). At a limit, above all of these: compound 2.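

In this assay, exchanging one amine tail for another left the number within the scatter, whereas formyl in place of the whole tail goes beyond it, with a 7.8-fold lower number from compound 3 to compound 4 (0.89 log units; beyond the scatter) and an 8.0-fold lower number from compound 1 to compound 4 (0.90 log units; beyond the scatter). The third step, an at least 12-fold lower number from compound 2 to compound 4 (1.09 log units; beyond the scatter), is only a floor, as compound 2 gives a limit and not a number: the limit of > 10000 nM in this assay, at which 1 of the 4 values shown sits.

At this position, the presence of an amine tail thus weighs more than its kind, and compound 4 gives the lowest number of the four. From the compounds shown here alone, whether formyl itself matters, or only the loss of the tail, stays open; a hydroxymethyl group, a carboxylic acid or a bare hydrogen at this place would separate the two.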